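The source may hold more compounds than are shown below. What is called first, only, known or untested is meant among the compounds shown, and "the series" means these compounds.

Compound 1 `C/C(=C\c1c[nH]c2ccccc12)C(=O)O`: > 100000 nM
Compound 2 `C/C(=C\c1c[nH]c2ccccc12)C(=O)Nc1ccc(C(F)(F)F)cc1`: 94900 nM

Both compounds were tested in an ADME assay on Huh-7 cells (Homo sapiens) for cytotoxicity, read by MTT assay, with a stated time of 72 h; on this read-out higher numbers stand for lower toxicity in this test and lower numbers for higher toxicity in this test. In this assay compound 1 gives > 100000 nM, which is a limit of the assay and not a number. Among the compounds with values here, compound 2 gives 94900 nM, the only numerical reading so far.

Compound 3 `C/C(=C\c1c[nH]c2ccccc12)C(=O)NCCN(C)C` has yet to be measured in this assay. It keeps the core of compound 1 and carries (2-(dimethylamino)ethyl)amino in place of hydroxy on a carbonyl carbon.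

Within the data shown here, no measured step is available to size this change, so the expectation rests on compound 2 at 94900 nM. A modest move towards lower numbers in this assay is expected, shown as the estimated step of an at least 1.6-fold lower number from compound 1 to compound 3 (0.22 log units; that floor lies within the scatter), and a result reported only as a limit remains possible. For compound 3 the expected value is 60000 nM, with an estimated range of 20000 nM to 120000 nM.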

Compound 3, half-maximal cytotoxic concentration: > 100000 nM
Compound 3 gave a limit, no number; the forecaster's own chance of this, stated with the estimate: 40%; middle value at least 1.6-fold (0.22 log units) from the limit.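

Compound 1 and compound 3 both give a limit and not a number in this assay, so no step between them can be read: the limit of > 100000 nM in this assay, at which 2 of the 3 values shown sit.

The compounds shown leave open whether (2-(dimethylamino)ethyl)amino in place of hydroxy on a carbonyl carbon moves the reading at all.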